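The source may report more compounds than this note shows. Statements on the series, on what has been measured and on what is new or still open speak of the compounds shown alone.

Of the compounds shown here, two sharing one core have so far been tested in a functional assay on HeLa cells (Homo sapiens) for cytotoxicity, read by MTT assay, with a stated time of 48 h; a higher number here means a weaker inhibitor, a lower number a stronger inhibitor. Compound 1 (`COc1ccc(/C=C/C(=O)/C=C/c2cc3ccccc3nc2Oc2ccccc2)cc1OC`) returned only a limit (> 10000 nM). Compound 2 (`COc1ccc(OC)c(/C=C/C(=O)/C=C/c2cc3ccccc3nc2Oc2ccc(Br)cc2)c1`) also returned only a limit (> 10000 nM). Compound 2 therefore has no number of its own and stands with compound 1 at that limit (the limit of > 10000 nM in this assay, at which 2 of the 2 values shown sit).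

Compound 3 (`COc1ccc(/C=C/C(=O)/C=C/c2cc3ccccc3nc2Oc2ccc(Br)cc2)cc1OC`) has the same atoms as compound 2, joined differently. It carries 3,4-dimethoxyphenyl in place of 2,5-dimethoxyphenyl on a double-bonded chain carbon bound to a double-bonded chain carbon. Among the compounds with values here, no measured step between two compounds shows what such a change does in this assay. Compound 1 also bears the 3,4-dimethoxyphenyl group, and its result is a limit (> 10000 nM). No step beyond the scatter is therefore expected, in either direction, and a further limit would be no surprise. The expected step (a step that the limit leaves unreadable from compound 2 to compound 3) is estimated to stay within the scatter. For compound 3 the estimated value is (12000 nM), with an expected range from (5000 nM) to (30000 nM).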

Compound 3, half-maximal inhibitory concentration: > 10000 nM
Compound 3: a limit, no number (the forecaster's own chance of this, stated with the estimate: 70%); the middle value does not contradict the limit.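

Compound 3, like compound 1 and compound 2, returned only a limit in this assay, so neither the step from compound 2 to compound 3 nor the step from compound 1 to compound 3 can be read: the limit of > 10000 nM in this assay, at which 3 of the 3 values shown sit. The compounds shown leave open what the exchange of dimethoxyphenyl groups or the bromo does to cytotoxicity.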